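The compounds below may be only part of what the source reports. "The series", "measured", "known", "first", "only" and "open" are said of these compounds alone.

Compound 1 `CS(=O)(=O)c1ccc(Cc2n[nH]c(=S)n2/N=C/c2cccnc2)cc1` stands at the lower end of the two numbers in hand: in a functional assay on HeLa cells (Homo sapiens) for cytotoxicity, read by MTT assay, with a stated time of 48 h, tested at 50 uM (a higher number here means a stronger effect of the compound at the concentration tested, a lower number a weaker effect), compound 1 gives 14%, while compound 2 `CS(=O)(=O)c1ccc(Cc2n[nH]c(=S)n2/N=C/c2ccccc2Cl)cc1` gives 42.7% in this assay, the step being a number 28.7 percentage points higher from compound 1 to compound 2 (beyond the scatter).

Compound 3 `CS(=O)(=O)c1ccc(Cc2n[nH]c(=S)n2/N=C/c2c(F)cccc2Cl)cc1` is not yet measured. Against compound 1 the change is 2-chloro-6-fluorophenyl in place of pyridin-3-yl on a carbon with a double bond to nitrogen.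

Among the compounds with values here, the only measured step that bears on this is the one from compound 1 to compound 2, where the pyridin-3-yl was likewise exchanged for a carbon-only ring carrying a chlorine, a number 28.7 percentage points higher from compound 1 to compound 2 (beyond the scatter). Within the data shown here, the entering group of compound 3 carries a fluorine as well as the chlorine, for which no measured step exists, so the expectation rests on the chlorine-bearing case alone: a rise of similar size in this assay is expected, a number 26 percentage points higher from compound 1 to compound 3 (beyond the scatter).

Compound 3 is therefore estimated at 40% in this assay, within 20% to 62%.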

Compound 3, a percentage reported as activity, at one concentration (the size of the read-out at that concentration, not a potency): 70.6%
Beside the measured number, compound 3's estimate is 30.6 percentage points below it; measured number outside the range, above it.
By their numbers in this assay, from the lowest: compound 1; then compound 2; then compound 3.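

In this assay the fluoro in place of hydrogen on an aromatic carbon counts on its own, with a number 27.9 percentage points higher from compound 2 to compound 3 (beyond the scatter), so the chlorine-bearing ring of compound 2 is not the end of the gain at this place. The full exchange of pyridin-3-yl for 2-chloro-6-fluorophenyl gives a number 56.6 percentage points higher from compound 1 to compound 3 (beyond the scatter), a large step on a carbon with a double bond to nitrogen. Compound 3 thus stands highest of the three, with its steps to compound 1 and compound 2 both beyond the scatter. Nothing at hand explains the effect of the fluoro. The compounds shown leave open whether fluoro gives a rise without the chlorine, and whether a methoxy group or an amine on this ring would do the same. From the compounds shown here alone, each read-out is also a single-concentration effect, so potency remains open.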